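This account rests on a few compounds, and the source may have more. Where it says the series, first, only, none or still open, it means among the compounds named here.

Measured compounds:
compound 1, `CCC1C(=O)N(C)c2cnc(-n3ccc4cc(C(=O)NCC(C)C)ccc43)nc2N1c1ccn(C)n1`: 5070 nM
compound 2, `CC[C@@H]1C(=O)N(C)c2cnc(-n3ccc4cc(C(=O)NC(C)C)ccc43)nc2N1C1CCCC1`: 1660 nM

Both compounds were tested in a functional assay on Huh-7 cells (Homo sapiens) for antiproliferative activity, read by CCK-8 assay, with a stated time of 72 h; on this read-out lower numbers stand for stronger inhibition of growth and higher numbers for weaker inhibition of growth. Compound 2 gives the lower number, 1660 nM, while compound 1 gives the higher one, 5070 nM, and the gap between them lies beyond the usual scatter, so compound 2 is the stronger growth inhibitor of this pair. Compound 3, `CCCCNC(=O)c1ccc2c(ccn2-c2ncc3c(n2)N(C2CCCC2)[C@H](CC)C(=O)N3C)c1`, has not yet been measured. It differs from compound 2 in a single place: butyl in place of isopropyl on an amide-type nitrogen. Going by the values given here, no measured pair differs in just this way, so there is no direct guide to the effect of the change. The rest of the molecule stays as in compound 2, and the step from compound 2 to compound 3 is expected to be small, a 1.2-fold higher number from compound 2 to compound 3 (0.08 log units; within the scatter), within the scatter in either direction. Compound 3 is therefore estimated at 2000 nM, with a range from 700 nM to 6000 nM.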

Compound 3, concentration for 50% growth inhibition: 683 nM
The estimate for compound 3 lay 2.9-fold (0.47 log units) above the measured number, outside the stated range (below it).
By their numbers in this assay, from the lowest: compound 3; then compound 2; then compound 1.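

In this assay, going by these compounds alone, butyl in place of isopropyl on the amide-type nitrogen gives a 2.4-fold lower number from compound 2 to compound 3 (0.39 log units; beyond the scatter) and is the first single change measured at this position. The step lies beyond the scatter, so the number responds to the chain on this nitrogen, even though neither group brings a ring, a hydrogen-bond donor or acceptor, or a charge. What lies behind the lower number cannot be told from the information available.

From the compounds shown here alone, whether a longer chain such as hexyl, or a butyl chain ending in an amine or a carboxylic acid, would lower the number further remains open. Going by these compounds, it is also open whether the same change would give a similar step where the rest of the molecule differs, as it does in compound 1.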